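The source may report more compounds than this note shows. Statements on the series, on what has been measured and on what is new or still open speak of the compounds shown alone.

Of the compounds shown here, three sharing a core have been measured in a functional assay on A549 cells (Homo sapiens) for cytotoxicity, read by MTT assay, with a stated time of 72 h; on this read-out lower numbers stand for stronger inhibition and higher numbers for weaker inhibition. Compound 1 `O=C(Nc1nnc(-c2cccc(O)c2O)s1)c1ccc(Cl)cc1` gives 9500 nM, compound 3 `Cc1ccc(C(=O)Nc2nnc(-c3cccc(O)c3O)s2)cc1` gives 11300 nM, and compound 2 `Cc1ccc(C(=O)Nc2nnc(-c3ccc(O)c(O)c3)s2)cc1` gives 11800 nM. Compound 2 lies within the scatter of both others, so these numbers do not separate the three.

Compound 4 `CC(=O)Nc1nnc(-c2ccc(O)c(O)c2)s1` keeps the rest of compound 2 but carries methyl in place of 4-methylphenyl on a carbonyl carbon. For the measured compounds named here, only one measured step offers any guide. That step, a 1.2-fold higher number from compound 1 to compound 3 (0.08 log units; within the scatter), is methyl in place of chloro on an aromatic carbon, so it swaps one small group on the aromatic ring and leaves the ring in place. Going by the values given here, the change to compound 4 removes that whole ring, and no measured compound lacks it, so the data give no direct measure of this change. Among the compounds with values here, the small size of the one measured step therefore says little here. A larger move is expected, towards a higher number in this assay, with wide uncertainty. The expected size is a 2.5-fold higher number from compound 2 to compound 4 (0.41 log units; beyond the scatter), probably just beyond the scatter. For compound 4 the estimated value is 30000 nM, with an expected range from 9000 nM to 100000 nM.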

Compound 4, half-maximal inhibitory concentration: 133000 nM
Compound 4: middle estimate off by 4.4-fold (0.65 log units), on the low side, and the stated range ends below it.
By their numbers in this assay, from the lowest: compounds 1, 3 and 2 (each within the scatter of the next); then compound 4.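

In this assay, methyl in place of 4-methylphenyl on a carbonyl carbon gives an 11-fold higher number from compound 2 to compound 4 (1.05 log units; beyond the scatter), a large loss of inhibition. For the compounds shown here, the only earlier step, methyl in place of chloro on the aromatic ring, gave a 1.2-fold higher number from compound 1 to compound 3 (0.08 log units; within the scatter) and stayed within the scatter, so the earlier compounds gave no sign that this end of the molecule could matter so much. The new step shows that removing the whole 4-methylphenyl group has a far larger effect on the number than that small swap on the ring, although nothing measured here explains the drop.

This single step removes an aromatic ring and several carbon atoms together, so it cannot tell whether the ring itself or simply the amount of carbon matters; a longer chain such as butyl or a non-aromatic ring such as cyclohexyl on the carbonyl carbon would help to separate the two. On these data alone, it also remains open whether the same loss would appear with the other arrangement of hydroxyl groups found in compound 3, and how an amine or a carboxylic acid on the retained aromatic ring would fare.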